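Aryl methyl removed from the core of compound 1

This account rests on a few compounds, and the source may have more. Where it says the series, first, only, none or still open, it means among the compounds named here.

Compound 1 `Cc1cccc(-c2n[nH]cc2N2CCCNCC2)c1` is tested in an assay on isolated protein for binding affinity to 5-hydroxytryptamine receptor 6 (Homo sapiens) (on this read-out higher numbers stand for weaker inhibition and lower numbers for stronger inhibition), where compound 1 gives 636 nM. Compound 2 `Fc1cccc(-c2n[nH]cc2N2CCCNCC2)c1` gives 841 nM in this assay; the step of a 1.3-fold higher number from compound 1 to compound 2 (0.12 log units; within the scatter) lies within the scatter, so compound 1 and compound 2 cannot be told apart on these numbers. Among the compounds with values here, compound 3 `COc1ccc(-c2n[nH]cc2N2CCCNCC2)cc1` returns only a limit in this assay, > 10000 nM, and this is the one value of the three that sits at the limit (the limit of > 10000 nM in this assay, at which 1 of the 3 values shown sits). Among the two real numbers, then, compound 1 and compound 2 stand together, with no order between them.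

Compound 4 `c1ccc(-c2n[nH]cc2N2CCCNCC2)cc1` differs from compound 1 by hydrogen in place of methyl on an aromatic carbon. Within the data shown here, no measured step removes a group at this position; the only step at this position, a 1.3-fold higher number from compound 1 to compound 2 (0.12 log units; within the scatter), exchanges one small group for another and stays within the scatter. That step therefore suggests the position tolerates small groups, but it does not show what a bare hydrogen does there. The expected step of a 1.9-fold higher number from compound 1 to compound 4 (0.28 log units; within the scatter) is thus small to moderate, with a slight lean toward a higher number. Compound 4 is estimated at 1200 nM in this assay, with a range from 400 nM to 4000 nM.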

Compound 4, inhibition constant: 3480 nM
Beside the measured number, compound 4's estimate is 2.9-fold (0.46 log units) below it; measured number inside the range.
By their numbers in this assay, from the lowest: compounds 1 and 2 (each within the scatter of the next); then compound 4. At a limit, above all of these: compound 3.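

In this assay, within the data shown here, hydrogen is the first group that separates from the others at this aromatic carbon: a 5.5-fold higher number from compound 1 to compound 4 (0.74 log units; beyond the scatter), and a 4.1-fold higher number from compound 2 to compound 4 (0.62 log units; beyond the scatter). Methyl and fluoro remain indistinguishable, with a 1.3-fold higher number from compound 1 to compound 2 (0.12 log units; within the scatter), so a group on this carbon matters here, while the choice between these two small groups does not show on these numbers. Compound 3 goes against any general rule that a group on the aromatic ring gives a lower number than hydrogen, with an at least 2.8-fold lower number from compound 3 to compound 4 (0.45 log units; beyond the scatter), but this step is bounded on one side only, as compound 3 stands at a limit: the limit of > 10000 nM in this assay, at which 1 of the 4 values shown sits.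

The compounds shown leave open whether chloro, trifluoromethyl or an amine on the aromatic carbon that carries the methyl in compound 1 would stay level with compound 1 and compound 2 or move the number further in either direction. They also leave open how far compound 3 truly lies from compound 4, and whether a methoxy on that same aromatic carbon would behave like methyl and fluoro.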